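Unsubstituted benzamide in a dichlorinated triazolopyridine series

The compounds below may be only part of what the source reports. "The series", "measured", "known", "first", "only" and "open" are said of these compounds alone.

compound 1 `O=C(Nc1ccc(Cl)c(-c2nnc3c(Cl)cccn23)c1)c1ccc(C(F)(F)F)cc1Cl`: > 100000 nM
compound 2 `O=C(Nc1ccc(Cl)c(-c2nnc3c(Cl)cccn23)c1)c1ccc(C(F)(F)F)cc1F`: > 100000 nM
compound 3 `Cc1cc(Cl)ccc1C(=O)Nc1ccc(Cl)c(-c2nnc3c(Cl)cccn23)c1`: > 100000 nM

In a functional assay on MDA-MB-231 cells (Homo sapiens) for antiproliferative activity, read by MTT assay, with stated times of 72 h and 4 h (on this read-out higher numbers stand for weaker inhibition and lower numbers for stronger inhibition), compound 1 gives only a limit, > 100000 nM. Compound 2 likewise reaches only a limit, > 100000 nM. Compound 3 also sits at a limit, > 100000 nM. The step that the two limits leave unreadable from compound 1 to compound 2 is thus not readable, and all three values share (the limit of > 100000 nM in this assay, at which 3 of the 3 values shown sit). Compound 4 `O=C(Nc1ccc(Cl)c(-c2nnc3c(Cl)cccn23)c1)c1ccccc1` differs from compound 3 by phenyl in place of 4-chloro-2-methylphenyl on a carbonyl carbon. Going by the values given here, no measured step resolves to a number, so the change offers nothing readable to build on. Compound 4 is therefore expected to remain at the limit, with a number no higher from compound 3 to compound 4 (the limit leaves the size open) of no readable size. The estimate for compound 4 in this assay is 100000 nM, between 30000 nM and 300000 nM.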

Compound 4, half-maximal inhibitory concentration: 58200 nM
For compound 4 the middle estimate is 1.7-fold (0.24 log units) above the measured one; low and high end bracket the measured number.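

Phenyl in place of 4-chloro-2-methylphenyl on a carbonyl carbon yields the first readable number of the series: in this assay compound 4 gives 58200 nM. The change amounts to an at least 1.7-fold lower number from compound 3 to compound 4 (0.23 log units; that floor lies within the scatter), which is a floor and not a measured size. The other steps in the series cannot be read: the limit of > 100000 nM in this assay, at which 3 of the 4 values shown sit.

From the compounds shown here alone, it stays open whether the loss of the chloro or of the methyl alone would produce this step. Also open, going by these compounds, is what an amine or a methoxy group on the phenyl would do to the number.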